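Swapping methoxy for chloro on compound 3

The compounds below may be only part of what the source reports. "The series", "measured", "known", "first", "only" and "open" are said of these compounds alone.

Compound 1 (`COc1ccc(-c2nc3ccccn3c2Nc2cc(OC)c(OC)c(OC)c2)cc1O`): 10000 nM
Compound 2 (`COc1ccc(-c2nc3cc(C)ccn3c2Nc2cc(OC)c(OC)c(OC)c2)cc1O`): 8000 nM
Compound 3 (`COc1ccc(-c2nc3cnccn3c2Nc2cc(OC)c(OC)c(OC)c2)cc1`): 54000 nM

In a functional assay on HEK-293T cells (Homo sapiens) for cytotoxicity, read by MTT assay (a lower number here means that less compound is tolerated, a higher number that more compound is tolerated), compound 3 stands highest at 54000 nM and lies beyond the scatter from both compound 1 and compound 2. Compound 4 (`COc1cc(Nc2c(-c3ccc(Cl)cc3)nc3cnccn23)cc(OC)c1OC`) differs from compound 3 by chloro in place of methoxy on an aromatic carbon, the change from 4-methoxyphenyl to 4-chlorophenyl. Going by the values given here, no measured pair tests this swap. Among the compounds with values here, the only measured single change, methyl in place of hydrogen (a 1.3-fold lower number from compound 1 to compound 2 (0.10 log units; within the scatter)), is a different one and stayed within the scatter, so it offers only weak guidance. The estimate therefore expects no step beyond the scatter (a 1.2-fold lower number from compound 3 to compound 4 (0.08 log units; within the scatter)). Compound 4 is estimated at 45000 nM (expected range 18000 nM to 100000 nM).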

Compound 4, concentration lethal to 50% of the cells: 25000 nM
For compound 4 the middle estimate is 1.8-fold (0.26 log units) above the measured one, within the range that was stated.
By their numbers in this assay, from the lowest: compounds 2 and 1 (each within the scatter of the next); then compound 4; then compound 3.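

In this assay, going by these compounds alone, chloro in place of methoxy gives the first step beyond the scatter between compounds differing in one place (a 2.2-fold lower number from compound 3 to compound 4 (0.33 log units; beyond the scatter)), so although modest, this change on the six-membered aromatic ring of carbon only does shift how much compound the cells tolerate. Nothing measured here explains why the number falls.

Going by these compounds, whether another group in this place, such as an amine or a carboxylic acid, would move the number further remains open. Also open, on these data alone, is whether the same swap would give a similar step on another core.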